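A few compounds are considered here, and "the series" means these few. Any claim that something is new, unique, unknown or untested is made for them only; others in the source may bear on it.

Working notes on the series.

Three compounds of the shared core carry different groups on a saturated chain carbon bound to an aromatic carbon. Compound 1 `COc1cccc(Cc2cnc(CCc3ccc(-c4ccccc4C(=O)O)cc3)[nH]2)c1` bears a 3-methoxyphenyl there; in an in vitro functional assay on cells for agonist activity at Bombesin receptor subtype-3 (Mus musculus), read by luminescence and calcium flux (on this read-out higher numbers stand for an effect only at larger amounts of compound and lower numbers for an effect already at smaller amounts), compound 1 gives 79 nM. Compound 2 `CC(C)(C)Cc1cnc(CCc2ccc(-c3ccccc3C(=O)O)cc2)[nH]1` bears a tert-butyl, and in this assay compound 2 gives 6.3 nM. Compound 3 `CCCCc1cnc(CCc2ccc(-c3ccccc3C(=O)O)cc2)[nH]1` bears a propyl, and in this assay compound 3 gives 93 nM. Compound 3 thus has the highest number of the three, but its nearest neighbour is compound 1: a 1.2-fold higher number from compound 1 to compound 3 (0.07 log units; within the scatter). Its distance from compound 2 is the large one: a 15-fold higher number from compound 2 to compound 3 (1.17 log units; beyond the scatter).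

Compound 4 `Cc1ccc(Cc2cnc(CCc3ccc(-c4ccccc4C(=O)O)cc3)[nH]2)cc1` is not yet measured. The change from compound 3 reads (4-methylphenyl in place of propyl on a saturated chain carbon bound to an aromatic carbon). For the measured compounds named here, the step that bears on this is the one from compound 1 to compound 3, where an aromatic ring on the same chain carbon was exchanged for propyl: a 1.2-fold higher number from compound 1 to compound 3 (0.07 log units; within the scatter). Going by the values given here, nothing among the measured compounds distinguishes 4-methylphenyl from 3-methoxyphenyl, so that step is the only guide; the large swing seen with tert-butyl, a 13-fold lower number from compound 1 to compound 2 (1.10 log units; beyond the scatter), concerns a group absent from compound 4 and is not taken as a guide.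

On that basis, compound 4 is expected to sit close to compound 3 in this assay, with a step of a 1.2-fold lower number from compound 3 to compound 4 (0.09 log units; within the scatter), not beyond the scatter. The estimate for compound 4 in this assay is 75 nM, with a range from 25 nM to 220 nM.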

Compound 4, half-maximal effective concentration: 162 nM
Beside the measured number, compound 4's estimate is 2.2-fold (0.33 log units) below it; measured number inside the range.
By their numbers in this assay, from the lowest: compound 2; then compounds 1, 3 and 4 (each within the scatter of the next, the first and the last beyond it).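

In this assay, the two aromatic groups on this saturated chain carbon are not interchangeable: the 3-methoxyphenyl and 4-methylphenyl pair shows a 2.1-fold higher number from compound 1 to compound 4 (0.31 log units; beyond the scatter), a modest gap, whereas the exchange of propyl for 4-methylphenyl stays within the scatter, with a 1.7-fold higher number from compound 3 to compound 4 (0.24 log units; within the scatter). For the compounds shown here, the tert-butyl also stands well apart from the new group, with a 26-fold higher number from compound 2 to compound 4 (1.41 log units; beyond the scatter), so that compound 2 remains the only compound of the four whose steps to all the others lie beyond the scatter. No supporting evidence is available that could account for any of these steps.

The compounds shown leave open whether the gap between 3-methoxyphenyl and 4-methylphenyl goes with the methoxy or methyl group itself or with its place on the ring, since the two groups differ in both; 4-methoxyphenyl or 3-methylphenyl would separate these readings. From the compounds shown here alone, it also remains open whether the low number of compound 2 is specific to tert-butyl or is shared by other saturated groups at this position, such as isopropyl, cyclohexyl or a longer branched chain.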